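This account rests on a few compounds, and the source may have more. Where it says the series, first, only, none or still open, it means among the compounds named here.

Measured in a functional assay on HepG2 cells (Homo sapiens) for inhibition, read by MTT assay, with a stated time of 72 h; a lower number here means a stronger inhibitor, a higher number a weaker inhibitor:
compound 1 `CN(C(=O)NC(=O)c1ccc(Cl)cc1Cl)c1nc(C(F)(F)F)c(C(=O)N/N=C/c2ccc(C(F)(F)F)cc2)s1` gives 12.4 ug/mL;
compound 2 `CN(C(=O)NC(=O)c1cccc(C(F)(F)F)c1)c1nc(C(F)(F)F)c(C(=O)N/N=C/c2ccc(C(F)(F)F)cc2)s1` gives 7.71 ug/mL;
compound 3 `CN(C(=O)NC(=O)c1ccc(Cl)cc1Cl)c1nc(C(F)(F)F)c(C(=O)N/N=C/c2cc(C(F)(F)F)cc(C(F)(F)F)c2)s1` gives only a limit of this assay, > 100 ug/mL.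

Compound 2 carries 3-(trifluoromethyl)phenyl in place of 2,4-dichlorophenyl on a carbonyl carbon relative to compound 1, and the step is a 1.6-fold lower number from compound 1 to compound 2 (0.21 log units; within the scatter). The difference between the core of compound 1 and the core of compound 3 is not broken down here. Compound 4 `CN(C(=O)NC(=O)c1cccc(C(F)(F)F)c1)c1nc(C(F)(F)F)c(C(=O)N/N=C/c2cc(C(F)(F)F)cc(C(F)(F)F)c2)s1` is still to be measured; it stands to compound 3 as compound 2 stands to compound 1, with the same change, (3-(trifluoromethyl)phenyl in place of 2,4-dichlorophenyl on a carbonyl carbon), at the same place. For compound 3 only the limit is known, as the limit of > 100 ug/mL in this assay, at which 1 of the 3 values shown sits, states. The step from compound 3 to compound 4 is expected to be small, a number no higher from compound 3 to compound 4 (the limit leaves the size open), because a 1.6-fold lower number from compound 1 to compound 2 (0.21 log units; within the scatter) lay within the scatter. Compound 4 is therefore expected to land around 100 ug/mL in this assay, with a range of 30 ug/mL to 300 ug/mL, and most likely to be reported again only as a limit.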

Compound 4, half-maximal inhibitory concentration: 5.38 ug/mL
Beside the measured number, compound 4's estimate is 19-fold (1.27 log units) above it; measured number outside the range, below it.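

In this assay, 3-(trifluoromethyl)phenyl in place of 2,4-dichlorophenyl on a carbonyl carbon gives an at least 18-fold lower number from compound 3 to compound 4 (1.26 log units; beyond the scatter). The size of this step does not carry over from one core to the other: the same change on two cores in this assay, a 1.6-fold lower number (0.21 log units; within the scatter) from compound 1 to compound 2 and an at least 18-fold lower number (1.26 log units; beyond the scatter) from compound 3 to compound 4, at least 11-fold (1.06 log units) apart, beyond the scatter of two such steps

Compound 3 is reported only as a limit of the assay, > 100 ug/mL, and the two pairs do not show what in the cores sets the steps apart.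

With only two cores shown, it remains open how the change behaves on any further core. Also open, on these data alone, is whether an amine or a carboxylic acid on the phenyl group at this carbonyl carbon would show the same dependence on the core.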